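The source may hold more compounds than are shown below. What is called first, only, known or untested is meant among the compounds shown, and "the series" means these compounds.

Compound 3 `N#CC1=C(N)Oc2c(N)cc3nc4ccccc4nc3c2C12C(=O)N(Cc1cnnn1-c1ccc(Cl)cc1)c1ccccc12` is among three close relatives tested in a functional assay on HepG2 cells (Homo sapiens) for antiproliferative activity, read by MTT assay, with a stated time of 48 h; on this read-out higher numbers stand for weaker inhibition and lower numbers for stronger inhibition. In this assay compound 3 gives > 50000 nM, which is a limit of the assay and not a number. Compound 1 `Cc1cccc(-n2nncc2CN2C(=O)C3(C(C#N)=C(N)Oc4c(N)cc5nc6ccccc6nc5c43)c3ccccc32)c1` gives > 50000 nM, also a limit. Compound 2 `N#CC1=C(N)Oc2c(N)cc3nc4ccccc4nc3c2C12C(=O)N(Cc1cnnn1-c1ccc(F)cc1)c1ccccc12` gives > 50000 nM, a limit as well. The steps a step that the two limits leave unreadable from compound 1 to compound 2, a step that the two limits leave unreadable from compound 1 to compound 3 and a step that the two limits leave unreadable from compound 2 to compound 3 therefore cannot be sized, because of the limit of > 50000 nM in this assay, at which 3 of the 3 values shown sit. Compound 4 `N#CC1=C(N)Oc2c(N)cc3nc4ccccc4nc3c2C12C(=O)N(Cc1cnnn1-c1ccccc1Cl)c1ccccc12` differs from compound 3 only in that (2-chlorophenyl in place of 4-chlorophenyl on an aromatic nitrogen). Going by the values given here, no measured step bears on moving the chloro substituent; with every value so far at the limit, the step that the limit leaves unreadable from compound 3 to compound 4 is expected to remain unreadable. Compound 4 is thus expected to give 80000 nM, within 30000 nM to 200000 nM.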

Compound 4, half-maximal inhibitory concentration: 33500 nM
The estimate for compound 4 lay 2.4-fold (0.38 log units) above the measured number; low and high end bracket the measured number.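

In this assay compound 4 is the first of these compounds to give a number and not a limit, so the aromatic group on this nitrogen can now be compared with a measured value on one side. The 2-chlorophenyl group gives an at least 1.4-fold lower number from compound 3 to compound 4 (0.17 log units; that floor lies within the scatter), an at least 1.4-fold lower number from compound 2 to compound 4 (0.17 log units; that floor lies within the scatter) and an at least 1.4-fold lower number from compound 1 to compound 4 (0.17 log units; that floor lies within the scatter). The steps among compound 1, compound 2 and compound 3 still cannot be read, because they share one ceiling: the limit of > 50000 nM in this assay, at which 3 of the 4 values shown sit.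

As far as these compounds go, it remains open whether a chlorine is needed at this ring position of compound 4. A 2-methylphenyl, 2-methoxyphenyl or 2-aminophenyl group in its place could test that.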